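This account rests on a few compounds, and the source may have more. Where it says the series, first, only, none or still open, it means among the compounds named here.

Measured in a functional assay on the whole organism (strain Sprague-Dawley) for inhibition, with Rattus norvegicus as the target, with a stated time of 10 min; on this read-out higher numbers stand for an effect only at larger amounts of compound and lower numbers for an effect already at smaller amounts:

- compound 1 `O=C(O)c1cnc(-c2ccc(Cl)cc2)[nH]c1=O`: 5 mg/kg
- compound 2 `O=C(O)c1cnc(-c2ccc(C(F)(F)F)cc2)[nH]c1=O`: > 5 mg/kg
- compound 3 `COc1ccc(-c2ncc(C(=O)O)c(=O)[nH]2)cc1`: > 5 mg/kg

Compound 1 is the only one of the three with an actual number, 5 mg/kg. Compound 2 reaches only a limit of the assay, > 5 mg/kg. Compound 3 also reaches only a limit, > 5 mg/kg. Together these limits make up (the limit of > 5 mg/kg in this assay, at which 2 of the 3 values shown sit).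

The next compound, compound 4 `CCOC(=O)c1cnc(-c2ccc(Cl)cc2)[nH]c1=O`, changes compound 1 at its acid: ethyl in place of hydrogen on an oxygen next to a carbonyl group, so that carboxy becomes ethoxycarbonyl (ethyl in place of hydrogen on an oxygen next to a carbonyl group).

Two measured steps start from compound 1, but both change the aromatic substituent rather than the carboxy group. One is a number no lower from compound 1 to compound 2 (the limit leaves the size open), and the other is a number no lower from compound 1 to compound 3 (the limit leaves the size open). Neither has a readable size, so they give only weak guidance. Within the data shown here, still, both changes to compound 1 ended at a limit, and no measured compound goes against that so far. A move toward a higher number in this assay therefore seems more likely than a move toward a lower one, and a limit rather than a number is quite possible.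

The expected change is a 2.0-fold higher number from compound 1 to compound 4 (0.30 log units; within the scatter). For compound 4 the estimate is 10 mg/kg, with an expected range from 3 mg/kg to 40 mg/kg.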

Compound 4, dose for 50% inhibition: > 30 mg/kg
Compound 4 was reported as a limit; the forecaster's own chance of this, stated with the estimate: 60%; middle value at least 3.0-fold (0.47 log units) away from the limit.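

The three earlier steps all change the substituent on the aromatic ring, and none of their sizes can be read. Among these compounds, this result is the first change at the carboxy group and the first step with a readable size, even though that size is only a minimum: in this assay it is an at least 6.0-fold higher number from compound 1 to compound 4 (0.77 log units; beyond the scatter). With the chloro substituent kept in place, turning carboxy into ethoxycarbonyl therefore brings an effect only at larger amounts of compound, and compound 4 stands at a limit of the assay rather than at a number: the limit of > 30 mg/kg in this assay, at which 1 of the 4 values shown sits.

Ethoxycarbonyl is the only replacement for carboxy shown here, so it remains open how a methyl ester, a primary amide or a nitrile at this place would compare, and whether a smaller group than ethyl on that oxygen would give a smaller step. Also open, as far as these compounds go, are how far beyond its limit compound 4 really lies and whether the same change would give a comparable step on the trifluoromethyl or methoxy compounds.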